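This account rests on a few compounds, and the source may have more. Where it says the series, first, only, none or still open, it means among the compounds named here.

Compound 1 `Nc1nc(C(F)(F)F)cc2c1[nH]c(=O)n2Cc1ccc(NCCN2CCCCC2)nc1` is one of two compounds for which a physicochemical assay for lipophilicity (on this read-out higher numbers stand for higher lipophilicity and lower numbers for lower lipophilicity), has been measured, and in this assay compound 1 gives 1.3, the lower of the two numbers. For the measured compounds named here, its only measured neighbour is compound 2 `Nc1nc(C(F)(F)F)cc2c1[nH]c(=O)n2Cc1ccc(NCc2ccccc2)nc1`, which in this assay gives 1.8; the change between them is a number 0.50 log units higher from compound 1 to compound 2 (beyond the scatter).

The step now followed leads from compound 1 to compound 3 `CN1CCN(CCN(C)c2ccc(Cn3c(=O)[nH]c4c(N)nc(C(F)(F)F)cc43)cn2)CC1`. The change is methyl(2-(4-methylpiperazin-1-yl)ethyl)amino in place of (2-(piperidin-1-yl)ethyl)amino on an aromatic carbon. Going by the values given here, no measured step touches this part of the molecule: the change from compound 1 to compound 2 concerns a different group, so nothing among the two measured compounds tells how this assay responds here. The expectation therefore rests on the counted difference alone, and a small step downward or none beyond the scatter is expected for compound 3, as a number 0.30 log units lower from compound 1 to compound 3 (within the scatter). Compound 3 is estimated at 1, with a range from 0.3 to 1.7.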

Compound 3, distribution coefficient: 1.5
Beside the measured number, compound 3's estimate is 0.50 log units below it, and the stated range covers the measured number.
By their numbers in this assay, from the lowest: compounds 1, 3 and 2 (each within the scatter of the next, the first and the last beyond it).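

At this position, on an aromatic carbon next to the ring nitrogen, putting methyl(2-(4-methylpiperazin-1-yl)ethyl)amino in place of (2-(piperidin-1-yl)ethyl)amino gives, in this assay, a number 0.20 log units higher from compound 1 to compound 3 (within the scatter), although the entering group has one more ring hetero atom and no hydrogen-bond donor. The same group in place of benzylamino gives a number 0.30 log units lower from compound 2 to compound 3 (within the scatter), so compound 3 lies within the scatter of both other compounds, while only the two earlier compounds stand apart beyond it. No measurement on hand accounts for this result.

The compounds shown leave open what the methyl on the chain nitrogen and the methylated second ring nitrogen each contribute; the two change together in compound 3. As far as these compounds go, how this assay responds to a morpholine ring or a longer chain here also remains open.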